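The source may report more compounds than this note shows. Statements on the series, on what has been measured and on what is new or still open speak of the compounds shown alone.

For the measured compounds named here, in a physicochemical assay for lipophilicity, read by HPLC (a higher number here means a more lipophilic compound, a lower number a more polar compound), compound 1 (`Cc1ccsc1C(=CCCN(C)C(CCN)C(=O)NCc1ccccc1Cl)c1sccc1C`) gives 6.11, its only single number, and one further entry has none. Compound 2 (`Cc1ccsc1C(=CCCN(C)C(CC(C)O)C(=O)NCc1ccccc1Cl)c1sccc1C`) gives 5.95; 5.67 (2 entries), and the several entries of compound 2 in this assay, 5.95; 5.67 (2 entries) shows how far entries for one compound can lie apart. Going by the values given here, no measured step is available for this series. Compound 3 (`Cc1ccc(CNC(=O)C(CCN)N(C)CCC=C(c2sccc2C)c2sccc2C)cc1`) carries 4-methylphenyl in place of 2-chlorophenyl on a saturated chain carbon bound to an amide-type nitrogen. No shift beyond the scatter is expected in this assay, starting from compound 1 at 6.11. The expected change is a number 0.01 log units lower from compound 1 to compound 3 (within the scatter). For compound 3 the estimated value is 6.1, with an expected range of 5.7 to 6.5.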

Compound 3, partition coefficient: 6.61
Estimate against measurement, compound 3: 0.51 log units below; measured number above the stated range.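

In this assay, the group on this saturated chain carbon bound to an amide-type nitrogen does register: 4-methylphenyl in place of 2-chlorophenyl gives a number 0.50 log units higher from compound 1 to compound 3 (beyond the scatter). For the compounds shown here, this is the first measured step, and it shows that an exchange keeping the heavy-atom count of the group can still move the read-out. The step is wider than the spread between repeat entries of one compound: the several entries of compound 2 in this assay, 5.95; 5.67 (2 entries)

The compounds shown do not separate the loss of chlorine from the gain of methyl, nor the 2- from the 4-substitution. On these data alone, whether plain phenyl or 4-chlorophenyl would read closer to compound 1 or compound 3 remains open.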